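Swapping the Side Group on the Ring Nitrogen

A few compounds are considered here, and "the series" means these few. Any claim that something is new, unique, unknown or untested is made for them only; others in the source may bear on it.

Of the compounds shown here, three sharing one core have been measured in a functional assay on MCF7 cells (Homo sapiens) for cytotoxicity, read by MTT assay, with a stated time of 24 h, tested at 32 ug/mL; a lower number here means a weaker effect, a higher number a stronger effect of the compound at the concentration tested. Compound 1 `Cn1cnnc1SCC(=O)Nc1ccc(-c2nc(-c3ccccc3)c(-c3ccccc3)n2C)cc1` gives 89.2%, compound 2 `Cc1nnc(SCC(=O)Nc2ccc(-c3nc(-c4ccccc4)c(-c4ccccc4)n3C)cc2)s1` gives 83.4%, and compound 3 `CN(C)/C=C/N1CCN(CC(=O)Nc2ccc(-c3nc(-c4ccccc4)c(-c4ccccc4)n3C)cc2)CC1` gives 25.8%, the lowest of the three. The step of a number 63.4 percentage points lower from compound 1 to compound 3 (beyond the scatter) and the step of a number 57.6 percentage points lower from compound 2 to compound 3 (beyond the scatter) both put the 4-(2-(dimethylamino)ethenyl)piperazin-1-yl group in place of a sulfanyl-linked heterocycle, so they speak to that whole group, not to what sits on its ring nitrogen. Compound 4 `COc1ccc(CN2CCN(CC(=O)Nc3ccc(-c4nc(-c5ccccc5)c(-c5ccccc5)n4C)cc3)CC2)cc1` keeps the piperazin-1-yl part and differs from compound 3 only there: 4-methoxybenzyl in place of 2-(dimethylamino)ethenyl on an amine nitrogen in a ring. For the measured compounds named here, no measured step tests such a change, so the expected step of a number 7.2 percentage points higher from compound 3 to compound 4 (within the scatter) is small and not clearly beyond the scatter. Compound 4 is therefore estimated at 33%, within 14% to 58%.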

Compound 4, a percentage reported as activity, at one concentration (the size of the read-out at that concentration, not a potency): 17.7%
Compound 4: middle estimate off by 15.3 percentage points, on the high side, and the stated range covers the measured number.
By their numbers in this assay, from the lowest: compounds 4 and 3 (each within the scatter of the next); then compounds 2 and 1 (each within the scatter of the next).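

In this assay, 4-methoxybenzyl in place of 2-(dimethylamino)ethenyl on an amine nitrogen in a ring gives a number 8.1 percentage points lower from compound 3 to compound 4 (within the scatter). For the compounds shown here, this is the first measured change at this position, and it shows that a group with an aromatic ring and a smaller open-chain group cannot be told apart here. No measured information explains this result. Still open, from the compounds shown here alone, is how this position would respond to a plain methyl, a bare hydrogen on that nitrogen, or a longer chain ending in a carboxylic acid.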